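Series notes: pyridinyl linker variation at the saturated ring carbon

The source may hold more compounds than are shown below. What is called first, only, known or untested is meant among the compounds shown, and "the series" means these compounds.

Measured compounds:
compound 1, `Cc1ccc(-n2nccn2)c(C(=O)N2C[C@H](C#Cc3cccnc3)CC[C@H]2C)c1`, 41 nM in an assay on cells for binding affinity to Orexin receptor type 2 (Homo sapiens), read by radioligand binding; a lower number here means a stronger inhibitor, a higher number a weaker inhibitor
compound 2, `Cc1ccc(-n2nccn2)c(C(=O)N2C[C@H](C#Cc3ccc(CO)nc3)CC[C@H]2C)c1`, 150 nM
compound 3, `Cc1ccc(-n2nccn2)c(C(=O)N2C[C@H](/C=C/c3ccc(F)cn3)CC[C@H]2C)c1`, 3 nM

Compound 3 stands lowest of the three numbers in this assay: the step of a 14-fold lower number from compound 1 to compound 3 (1.14 log units; beyond the scatter) and the step of a 50-fold lower number from compound 2 to compound 3 (1.70 log units; beyond the scatter) are both beyond the scatter. Compound 4, `Cc1ccc(-n2nccn2)c(C(=O)N2C[C@H](C#Cc3ccc(CO)cn3)CC[C@H]2C)c1`, is not yet measured. It differs from compound 3 by 2-(5-(hydroxymethyl)pyridin-2-yl)ethynyl in place of 2-(5-fluoropyridin-2-yl)ethenyl on a saturated ring carbon.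

Among the compounds with values here, two measured steps bear on this change. The step of a 14-fold lower number from compound 1 to compound 3 (1.14 log units; beyond the scatter) shows that moving from a triple bond with a pyridin-3-yl group to a double bond with a 5-fluoropyridin-2-yl group gave a large gain; compound 4 reverses this toward the triple bond. The step of a 3.7-fold higher number from compound 1 to compound 2 (0.56 log units; beyond the scatter) shows that adding hydroxymethyl on an aromatic carbon cost a modest amount. Compound 4 carries both the triple bond and a hydroxymethyl group, so a large increase in this assay from compound 3 is expected, with compound 4 expected to land near compound 2. The expected step is a 33-fold higher number from compound 3 to compound 4 (1.52 log units; beyond the scatter). For compound 4 the estimate is 100 nM, with a range from 30 nM to 350 nM.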

Compound 4, inhibition constant: 130 nM
Beside the measured number, compound 4's estimate is 1.3-fold (0.11 log units) below it; the measured number falls inside the stated range.
By their numbers in this assay, from the lowest: compound 3; then compound 1; then compounds 4 and 2 (each within the scatter of the next).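

In this assay, the step of a 1.2-fold lower number from compound 2 to compound 4 (0.06 log units; within the scatter) shows that, with hydroxymethyl on the pyridine and the triple bond kept, 5-(hydroxymethyl)pyridin-2-yl and 6-(hydroxymethyl)pyridin-3-yl cannot be told apart. The step of a 3.2-fold higher number from compound 1 to compound 4 (0.50 log units; beyond the scatter) shows a modest cost for 5-(hydroxymethyl)pyridin-2-yl in place of pyridin-3-yl on the triple-bonded carbon, so a second hydroxymethyl-bearing pyridine on that carbon also gives a higher number than the unsubstituted pyridin-3-yl. The step of a 43-fold higher number from compound 3 to compound 4 (1.64 log units; beyond the scatter) is large, and a pyridin-2-yl group on the triple-bonded carbon does not by itself bring the number back to that of compound 3. No measurement here explains these steps.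

Going by these compounds, how much of the large step belongs to the linker and how much to fluoro versus hydroxymethyl remains open, and 2-(5-fluoropyridin-2-yl)ethynyl would separate the two. On these data alone, whether an aminomethyl group or a carboxylic acid in the hydroxymethyl position behaves alike is also open.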